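The source may hold more compounds than are shown below. What is called first, only, known or untested is meant among the compounds shown, and "the series" means these compounds.

Compound 3 is `N=C(N)c1ccc(-c2ccc(-c3ccc(Cl)cc3)s2)cc1F`. In a functional assay on HCT-15 cells (Homo sapiens) for inhibition, read by sulforhodamine B assay, with a stated time of 48 h (a higher number here means a weaker inhibitor of growth, a lower number a stronger inhibitor of growth), compound 3 gives 172 nM, the lowest of the three numbers in hand, yet compound 2 `N=C(N)c1ccc(-c2ccc(-c3ccc(F)cc3)s2)cc1` with 252 nM and compound 1 `N=C(N)c1ccc(-c2ccc(-c3cc(Cl)cc(Cl)c3)s2)cc1` with 255 nM both lie within the scatter of that figure, so no order among the three can be drawn. Compound 4 is `COc1ccc(-c2ccc(-c3ccc(C(=N)N)c(F)c3)s2)cc1`. Its change from compound 3: methoxy in place of chloro on an aromatic carbon. Within the data shown here, no step between measured compounds shows the effect of methoxy in place of chloro, and the three measured numbers sit close together. The expected step is therefore small, of no clear direction beyond the scatter, as a 1.2-fold higher number from compound 3 to compound 4 (0.07 log units; within the scatter). Compound 4 is estimated to give 200 nM in this assay, within a range from 90 nM to 450 nM.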

Compound 4, concentration for 50% growth inhibition: 2580 nM
Beside the measured number, compound 4's estimate is 13-fold (1.11 log units) below it; the measured number lies above the stated range.
By their numbers in this assay, from the lowest: compounds 3, 2 and 1 (each within the scatter of the next); then compound 4.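

The position para to a large group is not indifferent to its substituent: methoxy in place of chloro on this aromatic carbon gives a 15-fold higher number from compound 3 to compound 4 (1.18 log units; beyond the scatter) in this assay. Among these compounds, this is the only readable single-place step, and the close numbers of the earlier compounds gave no hint of a change this large. Nothing at hand accounts for the step.

From the compounds shown here alone, whether a methyl, hydroxy or amino group at this position stays close to chloro or falls with methoxy remains open. Also open, going by these compounds, is whether the same step would appear on the core of compound 2.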